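Swapping Pyrazin-2-yl for Pyridin-4-yl: an Expected Step

This account rests on a few compounds, and the source may have more. Where it says the series, first, only, none or still open, it means among the compounds named here.

Of the compounds shown here, three have so far been tested in a functional assay on BJAB cells (Homo sapiens) for antiproliferative activity, with a stated time of 4 days; on this read-out lower numbers stand for an effect already at smaller amounts and higher numbers for an effect only at larger amounts of compound. Compound 1 `CCSc1sc(-n2nc(C)c(Cc3ccccc3[N+](=O)[O-])c2C(=O)O)nc1-c1ccc(Cl)c(Cl)c1` gives 59000 nM, compound 2 `Cc1nn(-c2nc(-c3ccc(Cl)c(Cl)c3)c(SC(C)C)s2)c(C(=O)O)c1-c1ccccc1` gives 3000 nM, and compound 3 `Cc1nn(-c2nc(-c3ccc(Cl)c(Cl)c3)c(SC(C)C)s2)c(C(=O)O)c1-c1cnccn1` gives 14000 nM. Compound 3 thus holds the second highest number of the three, its value sitting between those of compound 2 and compound 1. Compound 4 `Cc1nn(-c2nc(-c3ccc(Cl)c(Cl)c3)c(SC(C)C)s2)c(C(=O)O)c1-c1ccncc1` differs from compound 3 in one place: pyridin-4-yl in place of pyrazin-2-yl on an aromatic carbon. Among the compounds with values here, the only measured step that bears on this change is a 4.7-fold higher number from compound 2 to compound 3 (0.67 log units; beyond the scatter), in which pyrazin-2-yl replaced phenyl and the number rose. Pyridin-4-yl lies between phenyl and pyrazin-2-yl in what it carries, so a drop smaller than that step is expected. Compound 4 is therefore estimated to give 7000 nM, with a range from 3000 nM to 16000 nM. This estimate means an expected 2.0-fold lower number from compound 3 to compound 4 (0.30 log units; within the scatter), a step close to the edge of the usual scatter.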

Compound 4, half-maximal effective concentration: 5900 nM
Compound 4: the middle estimate sits 1.2-fold (0.07 log units) above what was measured; the range from low to high includes it.
By their numbers in this assay, from the lowest: compounds 2 and 4 (each within the scatter of the next); then compound 3; then compound 1.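

In this assay the change from pyrazin-2-yl to pyridin-4-yl gives a 2.4-fold lower number from compound 3 to compound 4 (0.38 log units; beyond the scatter) while the change from phenyl to pyridin-4-yl gives a 2.0-fold higher number from compound 2 to compound 4 (0.29 log units; within the scatter) so at this position, among these three rings, only pyrazin-2-yl stands apart. A ring with one nitrogen cannot be told from the phenyl ring on this read-out. No measurement shown explains why the pyrazin-2-yl ring differs.

Still open, from the compounds shown here alone, is whether moving the ring nitrogen, as in pyridin-3-yl, changes the number. Also open, going by these compounds, is how an amine or a longer carbon chain would fare in place of these rings.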